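Aryl sulfonate anilides: amide-to-urea swap at the amide terminus

A few compounds are considered here, and "the series" means these few. Any claim that something is new, unique, unknown or untested is made for them only; others in the source may bear on it.

Measured so far:
Compound 1 `CCCC(=O)Nc1cccc(S(=O)(=O)Oc2ccccc2C(C)C)c1` gives 9400 nM in a functional assay on MCF7 cells (Homo sapiens) for antiproliferative activity, read by sulforhodamine B assay, with a stated time of 48 h; on this read-out higher numbers stand for weaker inhibition and lower numbers for stronger inhibition.
Compound 2 `CC(C)c1ccccc1OS(=O)(=O)c1ccc(NC(=O)C(C)(C)C)cc1` gives 6500 nM in this assay.
Compound 3 `CC(C)(C)C(=O)Nc1ccc(S(=O)(=O)Oc2ccccc2I)cc1` gives 6600 nM in this assay.

Compound 2 stands at the lowest of the three numbers in this assay, but its nearest neighbour compound 3 sits within the scatter of it, and the furthest, compound 1, is also within the scatter; the three measured compounds are thus not separated on this read-out.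

Compound 4 `CCCCCNC(=O)Nc1ccc(S(=O)(=O)Oc2ccccc2C(C)C)cc1` is the next member. It differs from compound 2 by pentylamino in place of tert-butyl on a carbonyl carbon.

Within the data shown here, no measured step touches this position. Among the measured compounds shown here, the only step available, a 1.0-fold higher number from compound 2 to compound 3 (0.01 log units; within the scatter), concerns the aryl sulfonate ring and not the amide terminus, so it bears on the change in compound 4 only by showing how flat the series is so far. Compound 1, which carries a shorter acyl chain and a different substitution pattern, also sits within the scatter of compound 2. With no step beyond the scatter anywhere in the set, the expectation for compound 4 is a step of a 1.1-fold higher number from compound 2 to compound 4 (0.03 log units; within the scatter) relative to compound 2, that is, no shift beyond the scatter in either direction.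

Compound 4 is therefore expected at 7000 nM in this assay, within a range of 2500 nM to 20000 nM.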

Compound 4, half-maximal inhibitory concentration: 4000 nM
Compound 4: the middle estimate sits 1.8-fold (0.24 log units) above what was measured; low and high end bracket the measured number.
By their numbers in this assay, from the lowest: compounds 4, 2, 3 and 1 (each within the scatter of the next, the first and the last beyond it).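

In this assay, among these compounds, the first measured change at the amide terminus (a 1.6-fold lower number from compound 2 to compound 4 (0.21 log units; within the scatter)) stays inside the scatter, so on this read-out pentylamino on the carbonyl carbon, with its nitrogen and its hydrogen-bond donor, cannot be told apart from tert-butyl. Among the compounds shown here, the earlier step (a 1.0-fold higher number from compound 2 to compound 3 (0.01 log units; within the scatter)) concerned only the aryl sulfonate ring, so the carbonyl substituent now has a reading of its own, and that reading is as flat as the one for the exchange of isopropyl and iodo. Nothing at hand speaks to a cause for this result.

This single pair leaves open how far the flat reading extends at this position: a shorter chain such as ethylamino, a longer chain such as octylamino, a ring such as cyclohexylamino or a carboxylic acid at the chain end could each read differently. Also open is whether pentylamino gives the same reading when paired with the iodo substituent of compound 3, as the urea is shown here only with isopropyl.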